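Sulfonyl to Carbonyl on the Shared Core

The compounds below may be only part of what the source reports. "The series", "measured", "known", "first", "only" and "open" are said of these compounds alone.

Of the compounds shown here, three built on one core have been measured in a functional assay on DLD-1 cells (Homo sapiens); a higher number here means a weaker inhibitor, a lower number a stronger inhibitor. Among the measured compounds shown here, compound 1 `CC(C)C/N=C(\S)N1CCN(c2ccc(N(Cc3c[nH]cn3)S(=O)(=O)c3ccccc3)cc2)CC1` gives 800 nM, and compound 2 `O=S(=O)(c1ccccc1)N(Cc1c[nH]cn1)c1ccc(N2CCN(C(=S)NC3CCCCC3)CC2)cc1` gives 1000 nM; the only single-point step among them, a 1.3-fold higher number from compound 1 to compound 2 (0.10 log units; within the scatter), concerns the group on an amine nitrogen in a ring and stays within the scatter. Compound 3 `N#Cc1ccc(Cn2cncc2CN(c2ccc(N3CCN(C(=O)c4ccc(Cl)s4)CC3)cc2)S(=O)(=O)c2ccccc2)cc1` gives 200 nM, the lowest of the three numbers, and its gaps to compound 1 and compound 2 both lie beyond the scatter.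

Compound 4 `COc1ccccc1C(=O)N(Cc1cncn1Cc1ccc(C#N)cc1)c1ccc(N2CCN(C(=O)c3ccc(Cl)s3)CC2)cc1` differs from compound 3 in one place: (2-methoxyphenyl)carbonyl in place of phenylsulfonyl on a nitrogen on an aromatic ring. For the measured compounds named here, no measured step touches this position, and the one step that is known, between compound 1 and compound 2, neither resembles this change nor moves beyond the scatter. The data therefore give no direction for this assay, and a step of modest size either way would be unsurprising; a small weakening is taken as the middle case. The estimated step is a 2.0-fold higher number from compound 3 to compound 4 (0.30 log units; within the scatter). Compound 4 is expected to give about 400 nM, within a range of 100 nM to 1600 nM.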

Compound 4, half-maximal inhibitory concentration: > 10000 nM
Compound 4 ended at the assay's limit; the forecaster's own chance of this, stated with the estimate: 3%; middle value at least 25-fold (1.39 log units) away from the limit.
By their numbers in this assay, from the lowest: compound 3; then compounds 1 and 2 (each within the scatter of the next). At a limit, above all of these: compound 4.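

Among the compounds shown here, the change of phenylsulfonyl to (2-methoxyphenyl)carbonyl on a nitrogen on an aromatic ring gives an at least 50-fold higher number from compound 3 to compound 4 (1.69 log units; beyond the scatter), so this position, which no earlier step touched, does not accept every group of similar size in the counts. For the compounds shown here, the only earlier step, a 1.3-fold higher number from compound 1 to compound 2 (0.10 log units; within the scatter), concerned another place and showed no such sensitivity. In this assay compound 4 gives > 10000 nM, which is a limit and not a number: the limit of > 10000 nM in this assay, at which 1 of the 4 values shown sits.

The single step swaps the sulfonyl for a carbonyl and brings in the 2-methoxy group together, so the compounds shown leave open which of the two carries the loss. As far as these compounds go, a plain phenylcarbonyl or a (2-methoxyphenyl)sulfonyl on this nitrogen would separate them, and the true size of the step stays unknown.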